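The compounds below may be only part of what the source reports. "The series", "measured", "known", "first", "only" and "open" are said of these compounds alone.

Measured so far in an assay on L cells for inhibition of Protein-serine O-palmitoleoyltransferase porcupine (Mus musculus), read by reporter gene assay, with a stated time of 24 h; a lower number here means that less compound is needed, a higher number that more compound is needed for the effect:
compound 1 `O=C(CSc1nc2c(c(=O)n1-c1ccccc1)SCC2)Nc1nc2ccc(Cl)cc2s1` gives 40 nM
compound 2 `COc1ccc(-n2c(SCC(=O)Nc3nc4ccc(C(F)(F)F)cc4s3)nc3c(c2=O)SCC3)cc1` gives 100 nM
compound 3 `COc1ccccc1-n1c(SCC(=O)Nc2nc3ccc(Cl)cc3s2)nc2c(c1=O)SCC2` gives 50 nM

Compound 4 `O=C(CSc1nc2c(c(=O)n1-c1ccccc1)SCC2)Nc1nc2ccc(C(F)(F)F)cc2s1` is still to be measured in this assay. It comes from compound 2 by the following change: hydrogen in place of methoxy on an aromatic carbon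

The same kind of change separates compound 3 from compound 1: hydrogen in place of methoxy on an aromatic carbon

The two places are not identical: in compound 2 the methoxy stands para to a large group, in compound 3 ortho to a large group, so the changes are of the same kind, not the same. In this assay the measured step was a 1.3-fold lower number from compound 3 to compound 1 (0.10 log units; within the scatter). The difference between the cores of compound 2 and compound 3 is not broken down here.

Because a 1.3-fold lower number from compound 3 to compound 1 (0.10 log units; within the scatter) stayed within the scatter, the step from compound 2 to compound 4 is expected to be similarly small, a 1.3-fold lower number from compound 2 to compound 4 (0.10 log units; within the scatter). In this assay compound 4 is expected near 80 nM, between 40 nM and 160 nM.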

Compound 4, half-maximal effective concentration: 40 nM
Estimate against measurement, compound 4: 2.0-fold (0.30 log units) above, and the stated range covers the measured number.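

In this assay, the two steps for hydrogen in place of methoxy can be set side by side, and they do not differ beyond what repeated measurement allows: the same change on two cores in this assay, a 1.3-fold lower number (0.10 log units; within the scatter) from compound 3 to compound 1 and a 2.5-fold lower number (0.40 log units; beyond the scatter) from compound 2 to compound 4, 2.0-fold (0.30 log units) apart, within the scatter of two such steps. The change therefore carries across these two cores as far as two pairs can show, with only a 2.5-fold lower number from compound 2 to compound 4 (0.40 log units; beyond the scatter) lying beyond the scatter, but the methoxy does not stand in the same place in compound 2 and compound 3, so place and core are not separated, and two pairs set no rule for the series. Trifluoromethyl in place of chloro shows no change at the digits printed from compound 1 to compound 4 (within the scatter).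

Still open, on these data alone, is whether an amine, a hydroxy group or a carboxylic acid on that aromatic ring would fit the same picture. Also open, as far as these compounds go, is how methoxy para to a large group reads with chloro on the other end of the molecule.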